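Swapping isopropyl for chloro: an expected cytotoxicity step

The source may hold more compounds than are shown below. What is called first, only, known or untested is meant among the compounds shown, and "the series" means these compounds.

Measured so far:
- compound 1, `CC(C)=CCOc1cc(Nc2nccs2)ccc1C(C)C`: 31000 nM
- compound 2, `CC(C)=CCOc1cccc(Nc2ncccn2)c1`: > 100000 nM
- compound 3, `CC(C)=CCOc1cc(Nc2ccccn2)ccc1C`: 35000 nM

In a functional assay on MT2 cells (Homo sapiens) for cytotoxicity (a higher number here means that more compound is tolerated, a lower number that less compound is tolerated), compound 1 gives 31000 nM. Compound 3 gives 35000 nM in this assay, and the two numbers sit within the usual scatter of each other, so nothing separates them. Compound 2 stands apart: its value in this assay is a limit rather than a number, (the limit of > 100000 nM in this assay, at which 1 of the 3 values shown sits), meaning the assay reports no figure for it. Among the two plain numbers, compound 1 carries the lower one, but only by a margin that does not count.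

Compound 4, `CC(C)=CCOc1cc(Nc2nccs2)ccc1Cl`, has not been measured in this assay. It differs from compound 1 in one place: chloro in place of isopropyl on an aromatic carbon. The rest of the molecule, including the (3-methylbut-2-en-1-yl)oxy group and the (1,3-thiazol-2-yl)amino group, is unchanged.

Among the compounds with values here, no measured pair shows what this particular swap does to tolerated concentration, so the expectation rests on compound 1 alone and on the modest size of the change. The step from compound 1 to compound 4 is expected to be small, a 1.3-fold higher number from compound 1 to compound 4 (0.11 log units; within the scatter), not clearly beyond the scatter in either direction. Compound 4 is therefore estimated at 40000 nM, with a likely range from 15000 nM to 100000 nM.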

Compound 4, half-maximal cytotoxic concentration: 26000 nM
For compound 4 the middle estimate is 1.5-fold (0.19 log units) above the measured one, and the stated range covers the measured number.
By their numbers in this assay, from the lowest: compounds 4, 1 and 3 (each within the scatter of the next). At a limit, above all of these: compound 2.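

In this assay, placing chloro where isopropyl stood, on the aromatic carbon para to a (1,3-thiazol-2-yl)amino group, gives a 1.2-fold lower number from compound 1 to compound 4 (0.08 log units; within the scatter), and this is the first pair shown that differs in one place only. Within the data shown here, it offers the first direct look at this position: isopropyl, with its 3 heavy atoms, gives way to chloro, a single heavy atom, and the two compounds cannot be told apart by the concentration of compound that the cells tolerate, so this one swap gives no sign that the group here matters for this read-out. Nothing measured here bears on why the two compounds read alike.

Still open, on these data alone, is whether a clearly different group on this carbon, such as an amine, a carboxylic acid or a longer chain, would move the number beyond the usual scatter. Also open, as far as these compounds go, is whether chloro and isopropyl would read alike once the (1,3-thiazol-2-yl)amino group or the (3-methylbut-2-en-1-yl)oxy group is replaced by something else.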